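This account rests on a few compounds, and the source may have more. Where it says the series, first, only, none or still open, it means among the compounds named here.

Within the data shown here, in an assay on CHO cells for displacement of a labelled ligand from adenosine receptor A2b (Homo sapiens), read by radioligand binding (on this read-out lower numbers stand for stronger inhibition and higher numbers for weaker inhibition), none of the three compounds measured so far has produced a number. Compound 1 `CCOc1cccc2cc(-c3ccc(OC)cc3)c(=O)oc12` gives > 30000 nM, which is a limit of the assay rather than a measured value. Compound 2 `CCOc1cccc2cc(-c3ccc([N+](=O)[O-])cc3)c(=O)oc12` gives > 30000 nM, again a limit. Compound 3 `COc1cccc2cc(-c3ccc([N+](=O)[O-])cc3)c(=O)oc12` likewise gives > 30000 nM, a limit and not a number. Because every value shown sits at the limit of > 30000 nM in this assay, at which 3 of the 3 values shown sit, the step that the two limits leave unreadable from compound 1 to compound 2 and the step that the two limits leave unreadable from compound 2 to compound 3 have no readable size, and neither says whether binding moved at all.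

Compound 4 `COc1ccc(-c2cc3cccc(OC)c3oc2=O)cc1` differs from compound 3 in one place: methoxy in place of nitro on an aromatic carbon. Among the measured compounds shown here, the only measured step that swaps the same two groups, a step that the two limits leave unreadable from compound 1 to compound 2, runs in the opposite direction and lies entirely at the limit, so it gives neither a size nor a direction to lean on.

With nothing in this assay pointing to a move, compound 4 is expected to remain at the limit, estimated at 30000 nM with a range from 10000 nM to 100000 nM. The expected step of a number no higher from compound 3 to compound 4 (the limit leaves the size open) is thus none beyond the scatter.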

Compound 4, inhibition constant: > 30000 nM
Compound 4 was reported as a limit; the forecaster's own chance of this, stated with the estimate: 85%; the middle value sits exactly at the limit.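

In this assay compound 4 gives > 30000 nM, a limit and not a number. Its steps from compound 3 and from compound 1 therefore cannot be read: the limit of > 30000 nM in this assay, at which 4 of the 4 values shown sit.

The compounds shown leave open whether either swap changes binding at all.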